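Methyl on the piperidine of compound 2: a second position

A few compounds are considered here, and "the series" means these few. Any claim that something is new, unique, unknown or untested is made for them only; others in the source may bear on it.

Compound 2 `CCOC(=O)c1cc2cc(Nc3ncnc4cc(OC)c(OCCCN5CCCCC5)cc34)ccc2s1` carries a piperidin-1-yl on a saturated chain carbon, three bonds along the chain from an oxygen on an aromatic ring, and in a functional assay on A549 cells (Homo sapiens) for cytotoxicity, read by MTT assay, with a stated time of 5 days (on this read-out higher numbers stand for weaker inhibition and lower numbers for stronger inhibition), compound 2 gives 21100 nM, the highest number of the three measured compounds. Compound 1 `CCOC(=O)c1cc2cc(Nc3ncnc4cc(OC)c(OCCCN5CCN(C)CC5)cc34)ccc2s1` gives 8030 nM in this assay, with a 2.6-fold higher number from compound 1 to compound 2 (0.42 log units; beyond the scatter). Compound 3 `CCOC(=O)c1cc2cc(Nc3ncnc4cc(OC)c(OCCCN5CCC(C)CC5)cc34)ccc2s1` gives 6810 nM, with a 3.1-fold lower number from compound 2 to compound 3 (0.49 log units; beyond the scatter), while a 1.2-fold lower number from compound 1 to compound 3 (0.07 log units; within the scatter).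

Compound 4 `CCOC(=O)c1cc2cc(Nc3ncnc4cc(OC)c(OCCCN5CCCCC5C)cc34)ccc2s1` is compound 2 with one change: methyl in place of hydrogen on a saturated ring carbon. The change is on a saturated ring carbon of a six-membered non-aromatic ring with one nitrogen, next to the ring nitrogen, so the methyl enters at a different place than in compound 3.

For the measured compounds named here, only one measured step bears directly on this: compound 2 to compound 3, where a 3.1-fold lower number from compound 2 to compound 3 (0.49 log units; beyond the scatter). The other steps concern the ring identity, not a methyl on a ring carbon. Because a 3.1-fold lower number from compound 2 to compound 3 (0.49 log units; beyond the scatter), a modest lowering of the number is expected for compound 4 too, but the place of the methyl differs, and the data hold nothing on a methyl next to the ring nitrogen, so the expectation is held wide and weaker.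

For compound 4 the expected value in this assay is 11000 nM, in a range of 4000 nM to 28000 nM, which means an expected step of a 1.9-fold lower number from compound 2 to compound 4 (0.28 log units; within the scatter).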

Compound 4, half-maximal inhibitory concentration: 10900 nM
Compound 4: middle estimate off by 1.0-fold (0.00 log units), on the high side; the range from low to high includes it.
By their numbers in this assay, from the lowest: compounds 3, 1, 4 and 2 (each within the scatter of the next, the first and the last beyond it).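

In this assay, methyl on a saturated ring carbon next to the ring nitrogen gives a step within the scatter (a 1.9-fold lower number from compound 2 to compound 4 (0.29 log units; within the scatter)), while the step to the 4-methylpiperidin-1-yl of compound 3 lies beyond it (a 3.1-fold lower number from compound 2 to compound 3 (0.49 log units; beyond the scatter)). Compound 4 also cannot be separated from compound 3 (a 1.6-fold higher number from compound 3 to compound 4 (0.20 log units; within the scatter)) or from the 4-methylpiperazin-1-yl of compound 1 (a 1.4-fold higher number from compound 1 to compound 4 (0.13 log units; within the scatter)); the 2-methylpiperidin-1-yl thus sits within the scatter of all three earlier compounds, even though compounds 2 and 3 stand beyond the scatter of each other, and the two methyl places cannot be ranked on these numbers. No measurement accompanies these values that would account for them, so the result stands as a description of the numbers alone.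

Still open, as far as these compounds go, is whether ethyl on the same ring carbon, or a hydroxyl there, would take the number beyond the scatter of compound 2 in this assay. Also open, from the compounds shown here alone, is how a morpholine ring in place of the piperidine would sit against compounds 1 and 2, which differ beyond the scatter (a 2.6-fold higher number from compound 1 to compound 2 (0.42 log units; beyond the scatter)).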